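Swapping phenyl for cyclopentylamino on compound 1

A few compounds are considered here, and "the series" means these few. Any claim that something is new, unique, unknown or untested is made for them only; others in the source may bear on it.

In a physicochemical assay for solubility (on this read-out lower numbers stand for lower solubility and higher numbers for higher solubility), compound 1 `CS(=O)(=O)c1ccc(-n2nc(C(F)(F)F)cc2-c2ccccc2)nc1` gives 50 ug/mL. Within the data shown here, its only measured neighbour, compound 2 `CS(=O)(=O)c1ccc(-n2nc(C(F)(F)F)c(C#N)c2-c2ccccc2)nc1`, gives 100 ug/mL, so the two cannot be told apart with confidence. A third relative, compound 3 `CS(=O)(=O)c1ccc(-n2nc(C(F)F)c(C#N)c2-c2ccccc2)cc1`, has the entry "not determined" (no result reported) and so offers no comparison.

The next compound to be measured is compound 4 `CS(=O)(=O)c1ccc(-n2nc(C(F)(F)F)cc2NC2CCCC2)nc1`. It keeps the core of compound 1 but carries cyclopentylamino in place of phenyl on an aromatic carbon. The two groups are the same size by heavy-atom count, but they differ in ring type.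

Among the measured compounds shown here, only one measured step can serve as a guide, and it is a different exchange, cyano in place of hydrogen on an aromatic carbon. For the measured compounds named here, that step, a 2.0-fold higher number from compound 1 to compound 2 (0.30 log units; within the scatter), shows no change that can be separated from ordinary scatter, and no measured compound tests the loss of phenyl. With so little evidence, no clear direction can be predicted in this assay, so no step beyond the scatter is expected. The expected step is a 1.3-fold lower number from compound 1 to compound 4 (0.10 log units; within the scatter), though it remains uncertain. For compound 4 the estimated value is 40 ug/mL, with an expected range from 12 ug/mL to 130 ug/mL.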

Compound 4, solubility: 25 ug/mL
Compound 4: middle estimate off by 1.6-fold (0.20 log units), on the high side, within the range that was stated.
By their numbers in this assay, from the lowest: compounds 4, 1 and 2 (each within the scatter of the next, the first and the last beyond it).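

In this assay, exchanging phenyl for cyclopentylamino gives a 2.0-fold lower number from compound 1 to compound 4 (0.30 log units; within the scatter), so compounds 1 and 4 cannot be told apart with confidence. Among these compounds, this is the first measured change at this position, and it is a substantial change in structure: a six-membered aromatic ring of carbon only gives way to a five-membered non-aromatic ring, and the entering group brings a hydrogen-bond donor and a hydrogen-bond acceptor, yet the step stays within the scatter. No independent measurement bears on why this exchange gives the number it does.

Because the ring and the linking nitrogen change together, this pair cannot show what either contributes alone; a cyclopentyl group attached directly to the aromatic carbon, or an open-chain butylamino group, would help separate the two. From the compounds shown here alone, it also remains open whether a charged or more strongly different group at this position, such as a carboxylic acid or a piperazine, would produce a step beyond the scatter.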